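A Methoxyphenyl Urea Weighed Against Its Measured Neighbours

A few compounds are considered here, and "the series" means these few. Any claim that something is new, unique, unknown or untested is made for them only; others in the source may bear on it.

Three ureas built on one shared core have been measured in a functional assay on PC-3 cells (Homo sapiens) for antiproliferative activity, read by MTT assay, with a stated time of 48 h; on this read-out higher numbers stand for weaker inhibition and lower numbers for stronger inhibition. Compound 1 `Cc1ccc(NC(=O)Nc2nnc(Sc3ncnc4scc(-c5ccncc5)c34)s2)cc1Cl` gives 4700 nM, compound 2 `Cc1ccc(NC(=O)Nc2nnc(Sc3ncnc4scc(-c5ccncc5)c34)s2)cc1` gives 2100 nM, and compound 3 `O=C(Nc1ccc(Cl)c(C(F)(F)F)c1)Nc1nnc(Sc2ncnc3scc(-c4ccncc4)c23)s1` gives 12100 nM. Compound 3 stands highest of the three numbers, its nearest neighbour being compound 1 and its furthest compound 2.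

Compound 4 `COc1cccc(NC(=O)Nc2nnc(Sc3ncnc4scc(-c5ccncc5)c34)s2)c1` has not yet been measured in this assay. It differs from compound 3 in one place: 3-methoxyphenyl in place of 4-chloro-3-(trifluoromethyl)phenyl on an amide-type nitrogen. Going by the values given here, no measured pair involves a methoxyphenyl group, so the two steps that end at compound 3 are the closest guide. Those steps, a 2.6-fold higher number from compound 1 to compound 3 (0.41 log units; beyond the scatter) and a 5.8-fold higher number from compound 2 to compound 3 (0.76 log units; beyond the scatter), both run beyond the scatter and show that the 4-chloro-3-(trifluoromethyl)phenyl group carries the highest number of the set, while the 3-chloro-4-methylphenyl and 4-methylphenyl groups sit beneath it. As far as these compounds go, on that basis a downward step of modest size is expected in this assay, roughly a 3.5-fold lower number from compound 3 to compound 4 (0.54 log units; beyond the scatter), though the methoxy group itself is untested and the range must stay wide. Compound 4 is therefore estimated at 3500 nM, expected to fall between 1400 nM and 9000 nM.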

Compound 4, half-maximal inhibitory concentration: 6800 nM
For compound 4 the middle estimate is 1.9-fold (0.29 log units) below the measured one, and the stated range covers the measured number.
By their numbers in this assay, from the lowest: compound 2; then compounds 1, 4 and 3 (each within the scatter of the next, the first and the last beyond it).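

In this assay the exchange of 4-chloro-3-(trifluoromethyl)phenyl for 3-methoxyphenyl on the amide-type nitrogen gives a 1.8-fold lower number from compound 3 to compound 4 (0.25 log units; within the scatter) and the comparison with the 3-chloro-4-methylphenyl urea gives a 1.4-fold higher number from compound 1 to compound 4 (0.16 log units; within the scatter) so neither step separates the 3-methoxyphenyl group from the group it replaces. Going by these compounds alone, this is the first oxygen-bearing group seen at this place, with one hydrogen-bond acceptor counted where 4-chloro-3-(trifluoromethyl)phenyl has none and with fewer heavy atoms, yet compounds 1, 3 and 4 cannot be told apart as neighbouring pairs by these steps. The comparison with the 4-methylphenyl urea gives a 3.2-fold higher number from compound 2 to compound 4 (0.51 log units; beyond the scatter) and, with its earlier steps to compound 1 and compound 3 also beyond the scatter, this leaves compound 2 as the most potent of the four in this set.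

As far as these compounds go, whether a plain phenyl group, or a phenyl group carrying an amine or a carboxylic acid, would sit with compound 2 or with the other three remains open. Nothing available here bears on why 4-methylphenyl stands apart from the other groups at this place.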